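A few compounds are considered here, and "the series" means these few. Any claim that something is new, unique, unknown or untested is made for them only; others in the source may bear on it.

Values in a functional assay on BV-2 cells (Mus musculus), read by Griess assay, with a stated time of 24 h (on this read-out lower numbers stand for stronger inhibition and higher numbers for weaker inhibition), are as follows
- compound 1 `CC1COC2(C=CC(=O)C=C2)N(c2ccccc2)C1=O` gives 1220 nM
- compound 2 `C=CCC1COC2(C=CC(=O)C=C2)N(c2ccccc2)C1=O` gives 1030 nM
- compound 3 `O=C1C=CC2(C=C1)OCC(Cc1ccc(Cl)cc1)C(=O)N2c1ccccc1` gives 540 nM

Compound 2 is second highest of the three numbers, but that place is not resolved. Both a 1.2-fold lower number from compound 1 to compound 2 (0.07 log units; within the scatter) and a 1.9-fold lower number from compound 2 to compound 3 (0.28 log units; within the scatter) stay within the scatter, and only a 2.3-fold lower number from compound 1 to compound 3 (0.35 log units; beyond the scatter) goes beyond it, modestly.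

Compound 4 (`O=C1C=CC2(C=C1)OCC(Cc1ccc(C(F)(F)F)cc1)C(=O)N2c1ccccc1`) has not been measured. The change from compound 2 is 4-(trifluoromethyl)phenyl in place of vinyl on a saturated chain carbon bound to a saturated ring carbon and amounts to 4-(trifluoromethyl)phenyl in place of vinyl on a saturated chain carbon bound to a saturated ring carbon.

The closest measured precedent is a 1.9-fold lower number from compound 2 to compound 3 (0.28 log units; within the scatter), with 4-chlorophenyl in place of vinyl at the same place. The step of a 2.3-fold lower number from compound 1 to compound 3 (0.35 log units; beyond the scatter) runs in the same direction. The step of a 1.2-fold lower number from compound 1 to compound 2 (0.07 log units; within the scatter) concerns vinyl in place of hydrogen and says little about the entering group. Among the compounds with values here, no compound with a 4-(trifluoromethyl)phenyl group has a value yet, so the precedent rests on a single aromatic group.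

In this assay a lower number of similar size is therefore expected, close to the edge of the scatter. The expected step is a 1.8-fold lower number from compound 2 to compound 4 (0.26 log units; within the scatter) as an estimate.

For compound 4 the estimated value is 560 nM with an expected range of 250 nM to 1150 nM as the working figures.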

Compound 4, half-maximal inhibitory concentration: 1650 nM
Compound 4: the middle estimate sits 2.9-fold (0.47 log units) below what was measured; the whole stated range lies below it.
By their numbers in this assay, from the lowest: compounds 3, 2, 1 and 4 (each within the scatter of the next, the first and the last beyond it).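

In this assay, an aromatic group on a saturated chain carbon bound to a saturated ring carbon does not by itself give the lower number, since trifluoromethyl in place of chloro on an aromatic carbon gives a 3.1-fold higher number from compound 3 to compound 4 (0.49 log units; beyond the scatter), a modest step but one beyond the scatter. The other two steps do not resolve compound 4 from the compounds without an aromatic group at this place: a 1.6-fold higher number from compound 2 to compound 4 (0.20 log units; within the scatter) and a 1.4-fold higher number from compound 1 to compound 4 (0.13 log units; within the scatter) both stay within the scatter, so 4-(trifluoromethyl)phenyl cannot be ranked against vinyl or hydrogen. No supporting data at hand explain why chloro and trifluoromethyl part here.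

As far as these compounds go, with only compound 3 and compound 4 carrying an aromatic group at this place, it remains open whether the separation belongs to the 4-chlorophenyl group alone or is part of a wider trend on that aromatic carbon. A plain phenyl, 4-fluorophenyl or 4-methoxyphenyl group in the same place would show whether such compounds fall with compound 3 or with compound 4, and an amine at the end of a longer chain remains an open question as well.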